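The source may report more compounds than this note shows. Statements on the series, on what has been measured and on what is new or still open speak of the compounds shown alone.

Compound 1 `O=C1/C(=C/c2ccncc2)CN(S(=O)(=O)c2ccc(Cl)cc2)C/C1=C\c1ccccc1F` was tested in a functional assay on HepG2 cells (Homo sapiens) for cytotoxicity, read by MTT assay, with a stated time of 24 h (a higher number here means a weaker inhibitor, a lower number a stronger inhibitor), and gave 5300 nM. Compound 2 `O=C1/C(=C/c2ccncc2)CN(S(=O)(=O)c2ccc(Br)cc2)C/C1=C\c1ccccc1F` gave 9300 nM in this assay. The two differ by bromo in place of chloro on an aromatic carbon and the step of a 1.8-fold higher number from compound 1 to compound 2 (0.24 log units; within the scatter) stays within the scatter. Compound 3 `O=C1/C(=C/c2cccnc2)CN(S(=O)(=O)c2ccc(Cl)cc2)C/C1=C\c1ccccc1C(F)(F)F` has a different core, and the difference between the two cores is not broken down here; in this assay compound 3 gave 3620 nM, its number being within the scatter of compound 1 but beyond it relative to compound 2. Compound 4 `O=C1/C(=C/c2cccnc2)CN(S(=O)(=O)c2ccc(Br)cc2)C/C1=C\c1ccccc1C(F)(F)F` repeats the same change on the core of compound 3, namely (bromo in place of chloro on an aromatic carbon). Because the earlier step of a 1.8-fold higher number from compound 1 to compound 2 (0.24 log units; within the scatter) was small, the step of a 1.8-fold higher number from compound 3 to compound 4 (0.25 log units; within the scatter) is expected to be of similar size. The number for compound 4 is therefore estimated at 6500 nM, within a range from 3500 nM to 12000 nM.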

Compound 4, half-maximal inhibitory concentration: 2730 nM
Compound 4: the middle estimate sits 2.4-fold (0.38 log units) above what was measured; measured number outside the range, below it.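

In this assay, bromo in place of chloro gives a 1.3-fold lower number from compound 3 to compound 4 (0.12 log units; within the scatter), so on the core of compound 3, as on the core of compound 1, the step stands within the scatter. The two steps also cannot be told apart: the same change on two cores in this assay, a 1.8-fold higher number (0.24 log units; within the scatter) from compound 1 to compound 2 and a 1.3-fold lower number (0.12 log units; within the scatter) from compound 3 to compound 4, 2.3-fold (0.37 log units) apart, within the scatter of two such steps. This shows that the change carried across these two cores without a step beyond the scatter, but it does not show a real rise on one core and a real fall on the other, and two pairs say nothing about further cores.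

From the compounds shown here alone, only chloro and bromo appear in this place, so how a methoxy group, an amine or a carboxylic acid there would read in this assay remains open.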